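Cyclic Amine Replaces Open Chain on Compound 3

The compounds below may be only part of what the source reports. "The series", "measured", "known", "first", "only" and "open" are said of these compounds alone.

Compound 3 `Cc1nn(C)c2c1C(c1cccc(Cl)c1)=NCCN2CCCN(C)C` shares its core with compound 1 `CCN1CCN=C(c2cccc(Cl)c2)c2c(C)nn(C)c21` and compound 2 `Cc1nn(C)c2c1C(c1cccc(Cl)c1)=NCCN2N=O`. In a functional assay on the whole organism for positive allosteric modulation, with Rattus norvegicus as the target (on this read-out lower numbers stand for an effect already at smaller amounts and higher numbers for an effect only at larger amounts of compound), compound 1 gives 0.63 mg/kg. Compound 2 gives 1.25 mg/kg; a 2.0-fold higher number from compound 1 to compound 2 (0.30 log units; within the scatter). For compound 3 the assay reports only a limit, > 10 mg/kg. The steps of an at least 15-fold higher number from compound 1 to compound 3 (1.20 log units; beyond the scatter) and an at least 8.0-fold higher number from compound 2 to compound 3 (0.90 log units; beyond the scatter) show that the side chain carrying an amine moves the dose out to the edge of what was tested (the limit of > 10 mg/kg in this assay, at which 1 of the 3 values shown sits). Compound 4 `Cc1nn(C)c2c1C(c1cccc(Cl)c1)=NCCN2CCN1CCCC1` differs by pyrrolidin-1-yl in place of (dimethylamino)methyl on a saturated chain carbon, two bonds along the chain from a nitrogen on an aromatic ring in a ring, so an amine stays in the side chain at the same place. Going by the values given here, no measured step compares two such chains. Compound 4 is therefore expected to remain near a limit, an estimated 15 mg/kg, with a range from 5 mg/kg to 40 mg/kg. That expectation means a step that the limit leaves unreadable from compound 3 to compound 4.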

Compound 4, minimum effective dose: > 10 mg/kg
Compound 4: a limit, no number; the forecaster's own chance of this, stated with the estimate: 65%; the middle value is on the limit's open side.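

Compound 4 also stands at a limit, not a number, in this assay: the limit of > 10 mg/kg in this assay, at which 2 of the 4 values shown sit.

With pyrrolidin-1-yl, tying the amine into a ring does not bring back the small doses of the simpler groups, with an at least 15-fold higher number from compound 1 to compound 4 (1.20 log units; beyond the scatter) and an at least 8.0-fold higher number from compound 2 to compound 4 (0.90 log units; beyond the scatter). The step between compound 3 and compound 4 cannot be read, so any difference between ring and open chain stays hidden.

As far as these compounds go, what remains open is whether the amine or the chain length goes with the loss. A hydroxyl in place of the amine, or a shorter chain ending in an amine, would separate the two.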